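Aryl imine of the shared core: cytotoxicity expected unchanged

The source may hold more compounds than are shown below. What is called first, only, known or untested is meant among the compounds shown, and "the series" means these compounds.

Measured compounds:
compound 1 `Nc1sc2c(c1-c1nc3ccccc3s1)CCCC2` — 253 ug/mL
compound 2 `Fc1ccccc1/C=N/c1sc2c(c1-c1nc3ccccc3s1)CCCC2` — 319 ug/mL

Compound 1 `Nc1sc2c(c1-c1nc3ccccc3s1)CCCC2` gives 253 ug/mL in an ADME assay on cells (Rhabdomyosarcoma cell, Homo sapiens) for cytotoxicity, read by MTT assay, with a stated time of 72 h; on this read-out lower numbers stand for higher toxicity in this test and higher numbers for lower toxicity in this test. Compound 2 `Fc1ccccc1/C=N/c1sc2c(c1-c1nc3ccccc3s1)CCCC2` gives 319 ug/mL and stands highest of the two numbers, though the step of a 1.3-fold higher number from compound 1 to compound 2 (0.10 log units; within the scatter) is within the scatter. Compound 3 `C(=C/c1ccccc1)\C=N\c1sc2c(c1-c1nc3ccccc3s1)CCCC2` carries the change (2-phenylethenyl in place of 2-fluorophenyl on a carbon with a double bond to nitrogen). Within the data shown here, the only measured step bears on it loosely, as it also altered the group on that nitrogen, and it was small. A shift of no more than the scatter is therefore expected, so that the step of a 1.1-fold lower number from compound 2 to compound 3 (0.03 log units; within the scatter) is estimated to be small. Compound 3 is expected to give 300 ug/mL, within a range from 150 ug/mL to 600 ug/mL.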

Compound 3, half-maximal cytotoxic concentration: 207 ug/mL
Compound 3: middle estimate off by 1.4-fold (0.16 log units), on the high side; the measured number falls inside the stated range.
By their numbers in this assay, from the lowest: compounds 3, 1 and 2 (each within the scatter of the next).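

In this assay, 2-phenylethenyl in place of 2-fluorophenyl on a carbon with a double bond to nitrogen gives a 1.5-fold lower number from compound 2 to compound 3 (0.19 log units; within the scatter), a change to the group on that carbon itself, which the step from compound 1 did not test. Exchanging a fluorine-bearing group for one with a double bond outside aromatic rings therefore stays within the scatter here. No available evidence gives a reason for this step. The compounds shown leave open whether the fluorine or the double bond matters alone, since both differ together. They also leave open whether an amine or a carboxylic acid on that aromatic ring would move the number beyond the scatter.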